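Longer Alkyl Chains and Cytotoxicity in HEL Cells

The compounds below may be only part of what the source reports. "The series", "measured", "known", "first", "only" and "open" are said of these compounds alone.

Four compounds share one core and differ only in the length of a straight alkyl chain attached to it. Compound 1 `CCCCc1cc2cn([C@H]3C[C@H](O)[C@@H](CO)O3)c(=O)nc2s1` was tested in a functional assay on HEL cells (Homo sapiens) for cytotoxicity (on this read-out higher numbers stand for lower toxicity in this test and lower numbers for higher toxicity in this test), and gave only a limit, > 200000 nM. Compound 2 `CCCCCCc1cc2cn([C@H]3C[C@H](O)[C@@H](CO)O3)c(=O)nc2s1` likewise gave only a limit in this assay, > 200000 nM. Among the compounds with values here, compound 3 `CCCCCCCCCCc1cc2cn([C@H]3C[C@H](O)[C@@H](CO)O3)c(=O)nc2s1` is the one compound with an actual number in this assay, 54000 nM. The steps of an at least 3.7-fold lower number from compound 1 to compound 3 (0.56 log units; beyond the scatter) and an at least 3.7-fold lower number from compound 2 to compound 3 (0.56 log units; beyond the scatter) both point the same way, while a step that the two limits leave unreadable from compound 1 to compound 2 cannot be read because both of its ends sit at the limit of > 200000 nM in this assay, at which 2 of the 3 values shown sit. Compound 4 `CCCCCCCCCCCCc1cc2cn([C@H]3C[C@H](O)[C@@H](CO)O3)c(=O)nc2s1` carries the change (ethyl in place of hydrogen on a saturated chain carbon, ten or more bonds along the chain from an aromatic carbon). Following the two readable steps, the step of a 2.2-fold lower number from compound 3 to compound 4 (0.33 log units; beyond the scatter) is expected to lower the number further, and compound 4 is estimated at 25000 nM, between 8000 nM and 80000 nM.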

Compound 4, half-maximal cytotoxic concentration: 49000 nM
Compound 4: middle estimate off by 2.0-fold (0.29 log units), on the low side; the measured number falls inside the stated range.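

In this assay, a 1.1-fold lower number from compound 3 to compound 4 (0.04 log units; within the scatter) shows that adding ethyl to the chain makes no readable difference. The drop seen earlier therefore does not clearly continue at this length, although the shorter chains still stand apart, with an at least 4.0-fold lower number from compound 2 to compound 4 (0.61 log units; beyond the scatter) and an at least 4.0-fold lower number from compound 1 to compound 4 (0.61 log units; beyond the scatter). Both of these steps start from a limit, so their full size stays unknown: the limit of > 200000 nM in this assay, at which 2 of the 4 values shown sit.

Still open, on these data alone, is whether a longer chain would leave the number level. Also open, as far as these compounds go, is what an amine or a carboxylic acid would do at this place.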